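The compounds below may be only part of what the source reports. "The series", "measured", "known", "first", "only" and "open" are said of these compounds alone.

Measured so far in a toxicity assay on KB cells (Homo sapiens) for cytotoxicity, read by fluorescence, with a stated time of 3 days; a lower number here means that less compound is needed, a higher number that more compound is needed for the effect:
Compound 1 `CCCCOC(=O)CNC(=O)[C@H](CSc1ccc([N+](=O)[O-])cc1[N+](=O)[O-])NC(=O)CC[C@H](NC(=O)c1ccccc1)C(=O)OCCCC`: > 300 uM, a limit of the assay.
Compound 2 `CCCCOC(=O)CNC(=O)[C@H](CSc1ccc([N+](=O)[O-])cc1[N+](=O)[O-])NC(=O)CC[C@H](NC(=O)OC(C)(C)C)C(=O)OCCCC`: 70.4 uM.
Compound 3 `CCCCOC(=O)CNC(=O)[C@H](CSc1ccc([N+](=O)[O-])cc1[N+](=O)[O-])NC(=O)CC[C@H](NC(C)=O)C(=O)OCCCC`: > 300 uM, a limit of the assay.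

For the measured compounds named here, compound 2 holds the only number among the three; the other two values are limits (the limit of > 300 uM in this assay, at which 2 of the 3 values shown sit). Compound 4 `CCCCOC(=O)CNC(=O)[C@H](CSc1ccc([N+](=O)[O-])cc1[N+](=O)[O-])NC(=O)CC[C@H](Nc1ccc([N+](=O)[O-])cc1[N+](=O)[O-])C(=O)OCCCC` differs from compound 2 by 2,4-dinitrophenyl in place of tert-butoxycarbonyl on an amine nitrogen. Going by the values given here, two measured steps bear on this change, both leaving the tert-butoxycarbonyl: an at least 4.2-fold lower number from compound 1 to compound 2 (0.62 log units; beyond the scatter) and an at least 4.2-fold higher number from compound 2 to compound 3 (0.62 log units; beyond the scatter). Each other group on that carbonyl carbon gave a higher number than tert-butoxy, so a higher number in this assay is expected for compound 4 as well, and the step of a 3.1-fold higher number from compound 2 to compound 4 (0.49 log units; beyond the scatter) is the estimate. Compound 4 is therefore expected at about 220 uM, between 70 uM and 600 uM.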

Compound 4, concentration for half-maximal effect: > 300 uM
Compound 4 ended at the assay's limit; the forecaster's own chance of this, stated with the estimate: 55%; at least 1.3-fold (0.13 log units) between middle value and limit.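

Setting 2,4-dinitrophenyl in place of tert-butoxycarbonyl on this amine nitrogen gave, in this assay, an at least 4.2-fold higher number from compound 2 to compound 4 (0.62 log units; beyond the scatter), so the rise is not confined to groups joined through a carbonyl carbon. The value of compound 4 is a limit of the assay. The steps from compound 1 and from compound 3 to compound 4 cannot be read: the limit of > 300 uM in this assay, at which 3 of the 4 values shown sit.

The compounds shown leave open whether a free amine or a benzyloxycarbonyl group on this nitrogen would give a readable number, as compound 2 does, or would also sit at the limit.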